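This account rests on a few compounds, and the source may have more. Where it says the series, first, only, none or still open, it means among the compounds named here.

In a physicochemical assay for solubility, in phosphate buffer, at pH 7.4 (on this read-out lower numbers stand for lower solubility and higher numbers for higher solubility), compound 1 `COCCn1cc(C(=O)C(=O)Nc2ccc(OCC(=O)O)nc2)c2ccccc21` gives <= 200000 nM, which is a limit and not a number. As far as these compounds go, compound 2 `COc1ccc(NC(=O)C(=O)c2cn(C(C)(C)COCC(=O)O)c3ccccc23)cn1` gives <= 200000 nM, likewise only a limit, so its exact position remains unknown. Compound 3 `CCn1cc(C(=O)C(=O)Nc2ccc(OC)nc2)c2ccccc21` carries ethyl in place of a group of 9 heavy atoms with no ring, on an aromatic nitrogen (a group of 2 heavy atoms (2 carbon; no ring) in place of a group of 9 heavy atoms (6 carbon, 3 oxygen; no ring), on an aromatic nitrogen). Among the measured compounds shown here, the change removes the only hydrogen-bond donor counted in the departing group, and no measured step gauges its effect. A fall well beyond the scatter is expected for the step that the limit leaves unreadable from compound 2 to compound 3. For compound 3, the estimated value is 6000 nM, within an expected range of 1000 nM to 40000 nM.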

Compound 3, solubility: 10000 nM
Compound 3: the middle estimate sits 1.7-fold (0.22 log units) below what was measured, and the stated range covers the measured number.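

The step from compound 2 to compound 3 cannot be read, because compound 2 carries only a limit: the limit of <= 200000 nM in this assay, at which 2 of the 3 values shown sit.

The compounds shown leave open how much solubility changes when ethyl replaces the larger group on the aromatic nitrogen.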